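Amino for chloro on the shared core of compound 1

The source may hold more compounds than are shown below. What is called first, only, known or untested is meant among the compounds shown, and "the series" means these compounds.

For the measured compounds named here, compound 1, `ClCc1cccc(Cn2cnc3c(Cl)nc(Cl)nc32)c1`, is the stronger of the two compounds measured so far. In a functional assay on SF-295 cells (Homo sapiens) for cytotoxicity, read by sulforhodamine B assay, with a stated time of 48 h (a lower number here means a stronger inhibitor of growth, a higher number a weaker inhibitor of growth), compound 1 gives 4360 nM, while compound 2, `ClCc1ccccc1Cn1cnc2nc(Cl)nc(Cl)c21`, gives 20000 nM in the same test, a gap that lies beyond the usual scatter. Compound 3, `Nc1nc(Cl)c2ncn(Cc3cccc(CCl)c3)c2n1`, has not yet been tested. It differs from compound 1 in one place: amino in place of chloro on an aromatic carbon. Going by the values given here, no pair of measured compounds shows this change, so its effect is not known from the numbers at hand. Only a small step, if any, is expected: the step from compound 1 to compound 3 is estimated at a 1.6-fold higher number from compound 1 to compound 3 (0.21 log units; within the scatter), which stays close to the scatter. Compound 3 is therefore expected to give about 7000 nM in this assay, with a plausible range from 2000 nM to 25000 nM.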

Compound 3, concentration for 50% growth inhibition: 3380 nM
Compound 3: middle estimate off by 2.1-fold (0.32 log units), on the high side; the range from low to high includes it.
By their numbers in this assay, from the lowest: compounds 3 and 1 (each within the scatter of the next); then compound 2.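

In this assay, for the compounds shown here, this pair gives the first direct reading of amino in place of chloro on an aromatic carbon: a 1.3-fold lower number from compound 1 to compound 3 (0.11 log units; within the scatter). At this place, between two ring nitrogen atoms, the chloro group of compound 1 can therefore be exchanged for amino without a step beyond the scatter. This reading comes from a single pair on the shared core, and it says nothing yet about the same exchange on the core of compound 2. No measurement shown here explains why the two compounds read alike. The compounds shown leave open whether a methylamino, dimethylamino, hydroxyl or methoxy group at this same place would also stay within the scatter of compound 1. They also leave open what amino would do in place of the other chloro group, which compound 3 keeps.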